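The compounds below may be only part of what the source reports. "The series", "measured", "known", "first", "only" and "open" are said of these compounds alone.

Measured so far:
compound 1, `Cc1ccc(CNC(=O)c2nc(-c3ccc(F)cc3)n(CC[C@@H](O)C[C@@H](O)CC(=O)O)c2C2CC2)cc1`, 1.7 nM
compound 2, `COc1cccc(CNC(=O)c2nc(-c3ccc(F)cc3)n(CC[C@@H](O)C[C@@H](O)CC(=O)O)c2C2CC2)c1`, 1.2 nM
compound 3, `CN(C)S(=O)(=O)c1ccc(CNC(=O)c2nc(-c3ccc(F)cc3)n(CC[C@@H](O)C[C@@H](O)CC(=O)O)c2C2CC2)cc1`, 4.9 nM

In an assay on microsomes from liver for inhibition of 3-hydroxy-3-methylglutaryl-coenzyme A reductase (Rattus norvegicus), read by scintillation counting, with stated times of 0.5 h and 0.75 h (on this read-out higher numbers stand for weaker inhibition and lower numbers for stronger inhibition), compound 3 stands with the highest number of the three; the steps into it read a 2.9-fold higher number from compound 1 to compound 3 (0.46 log units; beyond the scatter) and a 4.1-fold higher number from compound 2 to compound 3 (0.61 log units; beyond the scatter), both beyond the scatter and both modest. The remaining measured step, a 1.4-fold lower number from compound 1 to compound 2 (0.15 log units; within the scatter), lies within the scatter, so the two lower compounds are not separated.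

Compound 4, `O=C(O)C[C@H](O)C[C@H](O)CCn1c(-c2ccc(F)cc2)nc(C(=O)NCc2ccc(F)cc2)c1C1CC1`, is not yet measured. Relative to compound 3 the change is fluoro in place of dimethylsulfamoyl on an aromatic carbon. Among the measured compounds shown here, the steps that bear on it are the two into compound 3, each showing a modest rise in number when the dimethylsulfamoyl enters on that aromatic carbon. Removing it again, with only a fluoro entering in its place, is expected to undo most of that rise; the estimated step is a 2.7-fold lower number from compound 3 to compound 4 (0.43 log units; beyond the scatter), toward a lower number, roughly returning to where compound 1 sits. Compound 4 is thus expected at 1.8 nM, range 0.9 nM to 3.6 nM.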

Compound 4, half-maximal inhibitory concentration: 3.4 nM
For compound 4 the middle estimate is 1.9-fold (0.28 log units) below the measured one; the measured number falls inside the stated range.
By their numbers in this assay, from the lowest: compounds 2, 1, 4 and 3 (each within the scatter of the next, the first and the last beyond it).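

In this assay, fluoro in place of dimethylsulfamoyl on the aromatic carbon gives a 1.4-fold lower number from compound 3 to compound 4 (0.16 log units; within the scatter), so a single fluorine and the six heavy atoms of dimethylsulfamoyl are not separated at this position, and the rise seen against methyl does not hold against fluoro. Fluoro in place of methyl gives a 2.0-fold higher number from compound 1 to compound 4 (0.30 log units; within the scatter), which places compound 4 unseparated from both compound 1 and compound 3, although those two are separated from each other, while the change of 3-methoxyphenyl to 4-fluorophenyl stands out as a 2.8-fold higher number from compound 2 to compound 4 (0.45 log units; beyond the scatter). Nothing measured here accounts for these steps.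

As far as these compounds go, how an amine or a carboxylic acid on this aromatic carbon would read remains open. A 4-methoxyphenyl or 3-fluorophenyl group would show whether the gap to compound 2 follows the group or its place on the ring.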